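Inverting both cyclopropane centres of compound 3

The source may hold more compounds than are shown below. What is called first, only, known or untested is meant among the compounds shown, and "the series" means these compounds.

In an assay on CHO cells for agonist activity at Neuronal acetylcholine receptor; alpha3/beta4 (Homo sapiens), read by FLIPR and calcium flux (a higher number here means a larger maximal response, a lower number a smaller maximal response), compound 1, drawn as `C[C@H]1C[C@H]1C(=O)N1CC2CNCC2C1`, gives 110%, compound 2, drawn as `C[C@@H]1C[C@@H]1C(=O)N1CC2CNCC2C1`, gives 180%, and compound 3, drawn as `C[C@@H]1C[C@H]1C(=O)N1CC2CNCC2C1`, gives 110%. Compound 3 therefore stands level with compound 1 at the digits shown, the two together being the lowest of the three numbers, and compound 2 lies a number 70 percentage points higher from compound 1 to compound 2 (beyond the scatter). The step of a number 70 percentage points lower from compound 2 to compound 3 (beyond the scatter) and the step of no change at the digits printed from compound 1 to compound 3 (within the scatter) complete the picture.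

Compound 4, drawn as `C[C@H]1C[C@@H]1C(=O)N1CC2CNCC2C1`, is related to compound 3 by the two compounds have the same atoms and bonds; at least one stereo element is drawn with a configuration in one of them and without one in the other: 2 of 4 stereo elements differ; a stereocentre at a saturated ring carbon is drawn R in compound 3 and S in compound 4; a stereocentre at a saturated ring carbon is drawn R in compound 3 and S in compound 4. Among the compounds with values here, the step that bears most directly on this change is the one between compound 1 and compound 2, where the same two centres are inverted together and the response moves a number 70 percentage points higher from compound 1 to compound 2 (beyond the scatter). A step of that kind can be large, but its direction for the present pair is not fixed by the earlier data. Compound 4 is expected to show a number 30 percentage points higher from compound 3 to compound 4 (beyond the scatter) in this assay, and its value is estimated at 140%, within 100% to 190%.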

Compound 4, largest response reached (Emax), in percent of the reference or control that the assay uses: 26%
For compound 4 the middle estimate is 114 percentage points above the measured one; measured number below the stated range.
By their numbers in this assay, from the lowest: compound 4; then compounds 1 and 3 (each within the scatter of the next); then compound 2.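

In this assay, inverting the same two saturated ring carbon centres now lowers the response (a number 84 percentage points lower from compound 3 to compound 4 (beyond the scatter)), whereas the earlier double inversion raised it (a number 70 percentage points higher from compound 1 to compound 2 (beyond the scatter)), so the outcome of this change depends on the configuration it starts from. Single inversions also prove far from neutral: compound 4 sits clearly under both of its single-centre neighbours (a number 84 percentage points lower from compound 1 to compound 4 (beyond the scatter); a number 154 percentage points lower from compound 2 to compound 4 (beyond the scatter)), while the earlier single inversion left the number unchanged (no change at the digits printed from compound 1 to compound 3 (within the scatter)). Compound 4 is thus the only one of the four whose steps to all the others are lower and beyond the scatter.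

As far as these compounds go, what remains open is whether this order of the four stereoisomers holds with an ethyl or a hydroxymethyl group in place of the methyl group. The compounds shown also do not tell why the configuration has such a large effect on the response.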